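Cyclopentyl to propyl on the oxygen-bound chain carbon

The compounds below may be only part of what the source reports. "The series", "measured", "known", "first", "only" and "open" are said of these compounds alone.

Measured so far:
compound 1 `CCCCCCOc1cccc(O)c1C(=O)/C=C/c1ccc(O)cc1`: > 30000 nM
compound 2 `O=C(/C=C/c1ccc(O)cc1)c1c(O)cccc1OCC1CCCC1`: 3040 nM

For the measured compounds named here, in a functional assay on PC-3 cells (Homo sapiens) for antiproliferative activity, read by sulforhodamine B assay (a lower number here means a stronger inhibitor of growth, a higher number a weaker inhibitor of growth), compound 2 gives 3040 nM, the only actual number so far. Compound 1 reads > 30000 nM, which is a limit of the assay and not a number.

The next step leads to compound 3 `CCCCOc1cccc(O)c1C(=O)/C=C/c1ccc(O)cc1`. The change is propyl in place of cyclopentyl on a saturated chain carbon bound to an oxygen on an aromatic ring.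

Going by the values given here, one measured step bears on this: an at least 9.8-fold lower number from compound 1 to compound 2 (0.99 log units; beyond the scatter), where cyclopentyl took the place of pentyl at the same position. That step has a limit at one end, so its true size is open on one side. It also ran from an open chain to the ring, and the step now in question runs the other way, though to a shorter chain than pentyl. A move towards weaker inhibition of growth is therefore expected, probably beyond the scatter but of uncertain size. The expected step is a 3.3-fold higher number from compound 2 to compound 3 (0.52 log units; beyond the scatter). For compound 3 the estimated value is 10000 nM, with an expected range from 3000 nM to 30000 nM.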

Compound 3, concentration for 50% growth inhibition: > 30000 nM
Compound 3: a limit, no number; the forecaster's own chance of this, stated with the estimate: 25%; at least 3.0-fold (0.47 log units) between middle value and limit.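

In this assay compound 3 reads > 30000 nM, a limit of the assay and not a number. Propyl in place of cyclopentyl gives an at least 9.8-fold higher number from compound 2 to compound 3 (0.99 log units; beyond the scatter), so the loss seen with pentyl at this position also appears with the shorter open chain, and among the three compounds only the one carrying cyclopentyl gives a number, with no compound here going against that pattern. The step between compound 1 and compound 3 cannot be read, so pentyl and propyl cannot be ordered at this position, and the series still rests on a single actual number: the limit of > 30000 nM in this assay, at which 2 of the 3 values shown sit.

The true size of the step to compound 3 stays open on one side, and the compounds shown do not separate the presence of the ring from the shape or size of the group, since no branched chain of similar size, such as isobutyl, stands beside cyclopentyl. As far as these compounds go, whether a cyclobutyl or cyclohexyl ring on the same saturated chain carbon, or an amine at the end of the chain, would give a number also remains open.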